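The source may report more compounds than this note shows. Statements on the series, on what has been measured and on what is new or still open speak of the compounds shown alone.

Compound 1 `O=S(=O)(Nc1ccc(-c2nc3ccccc3o2)cc1)c1cccc(Cl)c1` carries a 3-chlorophenyl on the sulfonyl sulfur, while compound 2 `O=S(=O)(Nc1ccc(-c2nc3ccccc3o2)cc1)c1ccc(F)cc1` carries a 4-fluorophenyl in the same place; the rest of the shared core is unchanged. In an assay on isolated protein for inhibition of malate dehydrogenase, mitochondrial (Sus scrofa), with stated times of 45 min and 30 min (a lower number here means a stronger inhibitor, a higher number a weaker inhibitor), compound 1 gives > 63000 nM, which is a limit of the assay rather than a measured number. In this assay compound 2 likewise gives > 63000 nM, again a limit and not a number. The step that the two limits leave unreadable from compound 1 to compound 2 therefore cannot be read in size. Compound 2 thus stands at the limit of > 63000 nM in this assay, at which 2 of the 2 values shown sit, with no real number for it anywhere in the set.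

Compound 3 `O=S(=O)(Nc1ccc(-c2nc3ccccc3o2)cc1)c1ccc(Cl)cc1` differs from compound 2 by chloro in place of fluoro on an aromatic carbon. For the measured compounds named here, no measured step bears on this change, since the only measured step joins two limits and gives no size at all. The expectation for compound 3 rests on those two limits alone, and the step expected is a step that the limit leaves unreadable from compound 2 to compound 3, none beyond the scatter. Compound 3 is estimated at 100000 nM, with a range from 30000 nM to 300000 nM, and the assay is expected most likely to report only a limit again.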

Compound 3, half-maximal inhibitory concentration: > 63000 nM
Compound 3: no number, only a limit; the forecaster's own chance of this, stated with the estimate: 85%; the middle value does not contradict the limit.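

In this assay compound 3 gives > 63000 nM, again a limit and not a number. The steps among compound 1, compound 2 and compound 3 therefore cannot be read in size. The compounds shown leave open how strongly, if at all, any of the three inhibits the enzyme, and whether swapping these substituents matters.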